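Compound 2 to compound 4: 4-fluorobenzyl to 3-chlorobenzyl

This account rests on a few compounds, and the source may have more. Where it says the series, first, only, none or still open, it means among the compounds named here.

In a functional assay on PC-3 cells (Homo sapiens) for cytotoxicity, read by MTT assay, with a stated time of 24 h (on this read-out lower numbers stand for stronger inhibition and higher numbers for weaker inhibition), compound 2 `COc1ccc(/C=C2\CN(C(=S)SCc3cn(Cc4ccc(F)cc4)nn3)C/C(=C\c3ccc(OC)cc3)C2=O)cc1` gives 45600 nM, within the scatter of compound 1 `COc1ccc(/C=C2\CN(C(=S)SCc3cn(Cc4ccccc4F)nn3)C/C(=C\c3ccc(OC)cc3)C2=O)cc1` at 31500 nM. Compound 3 `O=C1/C(=C/c2ccccc2F)CN(C(=S)SCc2cn(Cc3ccccc3Cl)nn2)C/C1=C\c1ccccc1F` gives > 80000 nM, which is a limit of the assay and not a number. For the measured compounds named here, the three results therefore include (the limit of > 80000 nM in this assay, at which 1 of the 3 values shown sits), and no compound here reads in the low range of this assay.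

Compound 4 `COc1ccc(/C=C2\CN(C(=S)SCc3cn(Cc4cccc(Cl)c4)nn3)C/C(=C\c3ccc(OC)cc3)C2=O)cc1` keeps the core of compound 2 and carries 3-chlorophenyl in place of 4-fluorophenyl on a saturated chain carbon bound to an aromatic nitrogen. Going by the values given here, one measured step bears on this place: a 1.4-fold higher number from compound 1 to compound 2 (0.16 log units; within the scatter). That single step swaps one fluorophenyl for another and offers no measured case of the chlorine change, so it is only a weak guide. No step beyond the scatter is expected in this assay, and the expected change is a 1.1-fold lower number from compound 2 to compound 4 (0.04 log units; within the scatter). A limit reading remains possible. The estimate for compound 4 is 42000 nM, with an expected range of 20000 nM to 80000 nM.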

Compound 4, half-maximal inhibitory concentration: > 80000 nM
Compound 4: only a limit was reported; the forecaster's own chance of this, stated with the estimate: 15%; at least 1.9-fold (0.27 log units) between middle value and limit.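

In this assay compound 4 reads > 80000 nM, which is a limit of the assay and not a number. This position on the shared core now gives a step beyond the scatter, an at least 2.5-fold higher number from compound 1 to compound 4 (0.40 log units; beyond the scatter), whereas the earlier swap between fluorophenyl groups stayed within it; the comparison with the 4-fluorophenyl analogue is less firm, with only a floor that lies within the scatter, an at least 1.7-fold higher number from compound 2 to compound 4 (0.24 log units; that floor lies within the scatter). A change at this one place is enough to take a compound on this core to the limit: the limit of > 80000 nM in this assay, at which 2 of the 4 values shown sit.

As far as these compounds go, how far compound 4 lies past its limit stays unknown, so neither step has a measured size beyond its floor. Also open, from the compounds shown here alone, is whether an amine or a carboxylic acid on the phenyl group at this place would give a reading in the low range of this assay.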